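A few compounds are considered here, and "the series" means these few. Any claim that something is new, unique, unknown or untested is made for them only; others in the source may bear on it.

Measured compounds:
- compound 1, `CN(C(=O)NC(=O)c1c(F)cccc1F)c1nc(C(F)(F)F)c(C(=O)N/N=C/c2cccc(C(F)(F)F)c2)s1`: 25.9 ug/mL
- compound 2, `CN(C(=O)NC(=O)c1ccc([N+](=O)[O-])cc1)c1nc(C(F)(F)F)c(C(=O)N/N=C/c2cccc(C(F)(F)F)c2)s1`: 1.67 ug/mL

Compound 1 stands with the highest of the two numbers in a functional assay on BCG823 cells (Homo sapiens) for inhibition, read by MTT assay, with a stated time of 72 h; a higher number here means a weaker inhibitor, a lower number a stronger inhibitor. Its nearest neighbour is compound 2, reached by a 16-fold lower number from compound 1 to compound 2 (1.19 log units; beyond the scatter), a change of the aryl group on a carbonyl carbon of the shared core.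

Compound 3, `CN(C(=O)NC(=O)c1c(F)cccc1F)c1nc(C(F)(F)F)c(C(=O)N/N=C/c2ccccc2C(F)(F)F)s1`, is not yet measured. It differs from compound 1 in 2-(trifluoromethyl)phenyl in place of 3-(trifluoromethyl)phenyl on a carbon with a double bond to nitrogen. Among the compounds with values here, the only measured step, from compound 1 to compound 2, alters a different part of the molecule, the aryl group on a carbonyl carbon, and so says nothing about moving the trifluoromethyl group on the aryl ring bound to the carbon with a double bond to nitrogen. Within the data shown here, no measured step bears on this change.

Among the measured compounds shown here, with no comparable step to draw on, compound 3 is expected to show no step beyond the scatter from compound 1, that is a 1.0-fold lower number from compound 1 to compound 3 (0.02 log units; within the scatter), though the range must be wide. The estimate for compound 3 in this assay is 25 ug/mL, with a range from 8 ug/mL to 80 ug/mL.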

Compound 3, half-maximal inhibitory concentration: 17 ug/mL
For compound 3 the middle estimate is 1.5-fold (0.17 log units) above the measured one; the range from low to high includes it.
By their numbers in this assay, from the lowest: compound 2; then compounds 3 and 1 (each within the scatter of the next).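

Where the step from compound 1 to compound 2 concerned the aryl group on a carbonyl carbon, this change concerns the aryl group on a carbon with a double bond to nitrogen, and in this assay 2-(trifluoromethyl)phenyl in place of 3-(trifluoromethyl)phenyl gives a 1.5-fold lower number from compound 1 to compound 3 (0.18 log units; within the scatter) as its result. Within the data shown here, with 2,6-difluorophenyl kept on the carbonyl carbon, these two placements of the trifluoromethyl group therefore do not separate compound 1 and compound 3 in this read-out, while the single change of the aryl group on the carbonyl carbon, a 16-fold lower number from compound 1 to compound 2 (1.19 log units; beyond the scatter), lies beyond the scatter. Nothing available accounts for either of these outcomes.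

Whether the two placements of the trifluoromethyl group would also read alike with 4-nitrophenyl on the carbonyl carbon remains an open question. Also open, from the compounds shown here alone, is how this position would respond to a different kind of group on the aryl ring, such as an amine or a carboxylic acid in place of trifluoromethyl.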